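Aryl hydrazone exchange on the shared core

This account rests on a few compounds, and the source may have more. Where it says the series, first, only, none or still open, it means among the compounds named here.

Compound 1 `COc1ccc(OC)c(/C=N/NC(=O)Nc2ccc(Oc3ccnc(-c4nncn4CCN(C)C)c3)c(F)c2)c1` gives 1950 nM in a functional assay on A549 cells (Homo sapiens) for cytotoxicity, read by MTT assay, with a stated time of 72 h (a lower number here means a stronger inhibitor, a higher number a weaker inhibitor), compound 2 `COc1ccc(/C=N/NC(=O)Nc2ccc(Oc3ccnc(-c4nncn4CCN(C)C)c3)c(F)c2)c(OC)c1` gives 2820 nM, and compound 3 `CN(C)CCn1cnnc1-c1cc(Oc2ccc(NC(=O)N/N=C/c3cccc(Cl)c3Cl)cc2F)ccn1` gives 1090 nM. Compound 3 carries the lowest number of the three, yet a 1.8-fold lower number from compound 1 to compound 3 (0.25 log units; within the scatter), while only a 2.6-fold lower number from compound 2 to compound 3 (0.41 log units; beyond the scatter). Compound 4 `COc1ccc(/C=N/NC(=O)Nc2ccc(Oc3ccnc(-c4nncn4CCN(C)C)c3)c(F)c2)cc1O` brings (3-hydroxy-4-methoxyphenyl in place of 2,3-dichlorophenyl on a carbon with a double bond to nitrogen). The measured steps that bear on this are the two exchanges of a dimethoxyphenyl for the 2,3-dichlorophenyl, a 1.8-fold lower number from compound 1 to compound 3 (0.25 log units; within the scatter) and a 2.6-fold lower number from compound 2 to compound 3 (0.41 log units; beyond the scatter). Compound 4 runs that exchange the other way, with a hydroxy where one methoxy stood, so in this assay a modest rise is expected, a 1.9-fold higher number from compound 3 to compound 4 (0.28 log units; within the scatter). Compound 4 is accordingly estimated at 2100 nM, in a range from 900 nM to 4800 nM.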

Compound 4, half-maximal inhibitory concentration: > 100000 nM
Compound 4: only a limit was reported; the forecaster's own chance of this, stated with the estimate: 3%; at least 47-fold (1.67 log units) between middle value and limit.
By their numbers in this assay, from the lowest: compounds 3, 1 and 2 (each within the scatter of the next, the first and the last beyond it). At a limit, above all of these: compound 4.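

At this position, on a carbon with a double bond to nitrogen, the earlier exchanges among 2,3-dichlorophenyl and the two dimethoxyphenyl groups stayed within the scatter or only modestly beyond it, whereas 3-hydroxy-4-methoxyphenyl brings a far larger shift: an at least 91-fold higher number from compound 3 to compound 4 (1.96 log units; beyond the scatter), an at least 35-fold higher number from compound 2 to compound 4 (1.54 log units; beyond the scatter) and an at least 51-fold higher number from compound 1 to compound 4 (1.70 log units; beyond the scatter). The position is therefore not indifferent to the aryl group carried there. The reading for compound 4 is a limit, not a number: the limit of > 100000 nM in this assay, at which 1 of the 4 values shown sits.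

As far as these compounds go, whether the loss follows the hydroxy itself stays open. A 3,4-dimethoxyphenyl or a 4-hydroxy-3-methoxyphenyl on the same carbon would bear on this.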